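The source may report more compounds than this note shows. Statements on the series, on what has been measured and on what is new or still open speak of the compounds shown alone.

In an in vitro functional assay on cells for agonist activity at Bombesin receptor subtype-3 (Homo sapiens), read by luminescence and calcium flux (on this read-out lower numbers stand for an effect already at smaller amounts and higher numbers for an effect only at larger amounts of compound), three compounds have been measured:

Compound 1 `CCCCc1cnc(CCc2ccc(-c3ccccc3C(=O)O)cc2)[nH]1` gives 2710 nM.
Compound 2 `CC(C)(C)c1cnc(CCc2ccc(-c3ccccc3C(=O)O)cc2)[nH]1` gives 4330 nM.
Compound 3 `O=C(O)c1ccccc1-c1ccc(CCc2ncc(CC3CCCC3)[nH]2)cc1` gives 133 nM.

Compound 3 stands lowest of the three; the nearest is compound 1, with a 20-fold lower number from compound 1 to compound 3 (1.31 log units; beyond the scatter), and the furthest compound 2, with a 33-fold lower number from compound 2 to compound 3 (1.51 log units; beyond the scatter). Compounds 1 and 2 lie within the scatter of each other, as a 1.6-fold higher number from compound 1 to compound 2 (0.20 log units; within the scatter) shows.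

Compound 4 `O=C(O)c1ccccc1-c1ccc(CCc2ncc(CC3CC3)[nH]2)cc1` differs from compound 3 in one place: cyclopropyl in place of cyclopentyl on a saturated chain carbon bound to an aromatic carbon. Both large steps seen so far end at compound 3, where the cyclopentyl sits, and both start from smaller groups in the same region: propyl in compound 1 and tert-butyl in compound 2. Compound 4 moves back toward a smaller group, so a rise of the number is expected in this assay, though cyclopropylmethyl is not identical to either of those smaller groups and the size is uncertain. Compound 4 is therefore estimated at 700 nM, within 200 nM to 2500 nM, which means an expected step of a 5.3-fold higher number from compound 3 to compound 4 (0.72 log units; beyond the scatter).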

Compound 4, half-maximal effective concentration: 1000 nM
Compound 4: the middle estimate sits 1.4-fold (0.15 log units) below what was measured; the range from low to high includes it.
By their numbers in this assay, from the lowest: compound 3; then compound 4; then compounds 1 and 2 (each within the scatter of the next).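

In this assay, going by these compounds alone, the change from cyclopentyl to cyclopropyl on a saturated chain carbon bound to an aromatic carbon gives a 7.5-fold higher number from compound 3 to compound 4 (0.88 log units; beyond the scatter) in a direct comparison of two rings, so the size of the ring counts at this position, which the earlier compounds could not show. The small ring still keeps part of the advantage over the open groups, with a 2.7-fold lower number from compound 1 to compound 4 (0.43 log units; beyond the scatter) for cyclopropyl in place of propyl and a 4.3-fold lower number from compound 2 to compound 4 (0.64 log units; beyond the scatter) for cyclopropylmethyl in place of tert-butyl, though these steps are modest beside the large ones that end at compound 3. No measurement at hand explains this dependence on ring size.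

From the compounds shown here alone, whether cyclobutyl would fall between compound 3 and compound 4 remains open. So does whether cyclohexyl or a ring carrying an amine would lower the number further at this position.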